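The compounds below may be only part of what the source reports. "The series", "measured", "known", "first", "only" and "open" are said of these compounds alone.

Measured compounds:
- compound 1 `Clc1ccc(C2ON=C(c3ccccc3Cl)O2)cc1Cl`; in an ADME assay on HEK293 cells (Homo sapiens) for cytotoxicity, read by MTT assay, with a stated time of 44 h (a lower number here means a stronger inhibitor, a higher number a weaker inhibitor), compound 1 gives > 100000 nM, which is a limit of the assay.
- compound 2 `Clc1ccc(C2ON=C(c3ccccc3Cl)O2)cc1`; in this assay compound 2 gives > 100000 nM, again a limit.

Compound 2 therefore stands at the ceiling of the numbers shown, not at a measured value. Hydrogen in place of chloro on an aromatic carbon gives a step that the two limits leave unreadable from compound 1 to compound 2; with both ends at a limit, nothing of its size can be read. Within the data shown here, the only evidence is the limit of > 100000 nM in this assay, at which 2 of the 2 values shown sit.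

Compound 3 `CC1(c2ccc(Cl)cc2)ON=C(c2ccccc2Cl)O1` differs from compound 2 by methyl in place of hydrogen on a saturated ring carbon. Among the measured compounds shown here, no measured step touches this ring position, and the one step is unreadable, so there is no size to carry over. In this assay compound 3 is expected to remain at the limit, the expected step of a number no higher from compound 2 to compound 3 (the limit leaves the size open) being none beyond the scatter. The estimate for compound 3 is 100000 nM, between 40000 nM and 300000 nM.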

Compound 3, half-maximal inhibitory concentration: > 100000 nM
Compound 3 ended at the assay's limit; the forecaster's own chance of this, stated with the estimate: 85%; the middle value lies on the limit itself.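

In this assay compound 3 gives > 100000 nM, which is a limit of the assay. The step from compound 2 to compound 3 therefore cannot be read, and no new size emerges. The compounds shown leave open whether any change to the shared core gives a measurable value in this assay.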